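A few compounds are considered here, and "the series" means these few. Any claim that something is new, unique, unknown or untested is made for them only; others in the source may bear on it.

Three ureas on the shared core have been measured in an assay on a protein complex for binding affinity to Neuronal acetylcholine receptor; alpha4/beta2 (Homo sapiens); a lower number here means a stronger inhibitor, a higher number a weaker inhibitor. Compound 1 `O=C(Nc1cccc(Br)c1)N[C@@H]1C2CCN(CC2)[C@@H]1Cc1cccnc1` reaches the limit of the assay and gives no number, > 10000 nM. Compound 2 `COc1ccccc1NC(=O)N[C@@H]1C2CCN(CC2)[C@@H]1Cc1cccnc1` likewise stops at a limit, > 10000 nM. Compound 3 `COc1cccc(NC(=O)N[C@@H]2C3CCN(CC3)[C@@H]2Cc2cccnc2)c1` also returns a limit rather than a number, > 10000 nM. The steps between them are therefore unreadable: a step that the two limits leave unreadable from compound 1 to compound 2, a step that the two limits leave unreadable from compound 1 to compound 3 and a step that the two limits leave unreadable from compound 2 to compound 3 cannot be sized, since (the limit of > 10000 nM in this assay, at which 3 of the 3 values shown sit). For the measured compounds named here, compound 3 thus stands where every member of the series so far stands, at the limit. Compound 4 `CSc1ccc(NC(=O)N[C@@H]2C3CCN(CC3)[C@@H]2Cc2cccnc2)cc1` is the next member; the change is 4-(methylsulfanyl)phenyl in place of 3-methoxyphenyl on an amide-type nitrogen. Going by the values given here, no measured step bears on it in a readable way; the three limits only show that no aryl variation so far has brought a value into the measurable range. The expectation for compound 4 in this assay is again a value at or beyond the limit, estimated at 15000 nM with a range from 4000 nM to 60000 nM. The expected step is a step that the limit leaves unreadable from compound 3 to compound 4, none beyond the scatter.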

Compound 4, inhibition constant: > 10000 nM
Compound 4: a limit, no number; the forecaster's own chance of this, stated with the estimate: 85%; the middle value does not contradict the limit.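

Compound 4 also returns a limit rather than a number, > 10000 nM. For the compounds shown here, no step from compound 1, compound 2 or compound 3 to compound 4 can be read in this assay: the limit of > 10000 nM in this assay, at which 4 of the 4 values shown sit. The compounds shown leave open whether any aryl group on this urea gives a measurable value.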